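A few compounds are considered here, and "the series" means these few. Any claim that something is new, unique, unknown or untested is made for them only; others in the source may bear on it.

Compound 1 `CCCN(CC1CC1)c1nc(C)nc(N(CC)c2ccc(N(C)C)cc2C(F)(F)F)n1` is measured in an assay on isolated protein for binding affinity to corticotropin-releasing factor receptor 1 (Homo sapiens); a lower number here means a stronger inhibitor, a higher number a weaker inhibitor. In this assay compound 1 gives 5 nM. Compound 3 `CCN(CC)c1cc(C)nc(N(CC)c2ccc(C(C)=O)cc2Br)n1` gives 5 nM in this assay, and compound 1 sits level with compound 3 at the digits shown, the two values lying within the usual scatter of each other. Compound 2 `CCN(c1ccc(C(C)C)cc1)c1nc(C)cc(C)n1` returns only a limit in this assay, > 1000 nM, which is not a number. This is the limit of > 1000 nM in this assay, at which 1 of the 3 values shown sits.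

Compound 4 `CCCN(CCC)c1nc(C)nc(N(CC)c2ccc(N(C)C)cc2C(F)(F)F)n1` differs from compound 1 by ethyl in place of cyclopropyl on a saturated chain carbon bound to a nitrogen on an aromatic ring; in words, ethyl in place of cyclopropyl on a saturated chain carbon bound to a nitrogen on an aromatic ring, so that cyclopropylmethyl becomes propyl and the (cyclopropylmethyl)(propyl)amino group becomes dipropylamino. Among the compounds with values here, no measured pair shows this step, so the expectation rests on compound 1 alone. Since the change touches few atoms and leaves the rest of compound 1 intact, the estimated step is a 1.2-fold higher number from compound 1 to compound 4 (0.08 log units; within the scatter) in this assay, not beyond the scatter in either direction. Compound 4 is therefore expected to give 6 nM, within a range of 2 nM to 20 nM.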

Compound 4, inhibition constant: 6 nM
Compound 4: the middle estimate sits on the measured number at the digits printed; the measured number falls inside the stated range.
By their numbers in this assay, from the lowest: compounds 1, 3 and 4 (each within the scatter of the next). At a limit, above all of these: compound 2.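

In this assay the change reads as a 1.2-fold higher number from compound 1 to compound 4 (0.08 log units; within the scatter), so on this saturated chain carbon bound to a nitrogen on an aromatic ring, ethyl can stand in place of cyclopropyl with no shift beyond the scatter. Within the data shown here, this is the first single-place comparison: it shows that, on the core of compound 1, the three-membered ring is not needed to hold the value, and that dipropylamino does as well as (cyclopropylmethyl)(propyl)amino. Nothing among the measurements shown accounts for this step.

Going by these compounds, how far this position stays open to other groups is unsettled, whether a longer chain such as butyl, a larger ring such as cyclobutyl, or a chain ending in an ether or an amine. On these data alone, whether the same exchange would hold with a different group in place of the dimethylamino or trifluoromethyl of compound 1 also remains unknown.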